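Three compounds at the assay limit, a fourth expected there

A few compounds are considered here, and "the series" means these few. Any claim that something is new, unique, unknown or untested is made for them only; others in the source may bear on it.

Compound 1 `Cc1ccc2c(NCc3ccc(NC(=O)C4CCN(Cc5ccccc5F)CC4)cc3)nc(N(C)C)nc2c1`, compound 2 `Cc1ccc2c(NCc3ccc(NC(=O)C4CCN(Cc5ccccc5)CC4)cc3)nc(N3CCC(N4CCCC4)CC3)nc2c1` and compound 3 `Cc1ccc2c(NCc3ccc(NC(=O)C4CCN(Cc5ccccc5)CC4)cc3)nc(N3CCNC(CCO)C3)nc2c1` share one core and differ only in the group attached to the aromatic carbon of the six-membered aromatic ring with 2 nitrogen. In a functional assay on SV5A8 cells (Homo sapiens) for cytotoxicity (a lower number here means a stronger inhibitor, a higher number a weaker inhibitor), compound 1 gives > 6670 nM, which is a limit of the assay and not a number. Compound 2 gives > 8090 nM in this assay, again a limit. Compound 3 gives > 8420 nM in this assay, also a limit. Compound 3 thus stands at a limit, as do the two other values shown (the limit of > 6670 nM in this assay, at which 1 of the 3 values shown sits, (the limit of > 8090 nM in this assay, at which 1 of the 3 values shown sits), (the limit of > 8420 nM in this assay, at which 1 of the 3 values shown sits)). Among the compounds with values here, the only step between measured compounds, a step that the two limits leave unreadable from compound 2 to compound 3, is unreadable, and no measured step gives a size for a change at this position.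

Compound 4 `Cc1ccc2c(NCc3ccc(NC(=O)C4CCN(Cc5ccccc5)CC4)cc3)nc(N(C)CCCN(C)C)nc2c1` differs from compound 3 by (3-(dimethylamino)propyl)(methyl)amino in place of 3-(2-hydroxyethyl)piperazin-1-yl on an aromatic carbon. Compound 4 is expected to sit at a limit as well, with an expected step that the limit leaves unreadable from compound 3 to compound 4 that stays within the scatter. The estimate for compound 4 in this assay is 10000 nM, with a range from 5000 nM to 30000 nM.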

Compound 4, half-maximal inhibitory concentration: > 8620 nM
Compound 4: no number, only a limit; the forecaster's own chance of this, stated with the estimate: 85%; the middle value does not contradict the limit.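

In this assay compound 4 gives > 8620 nM, which is a limit of the assay and not a number. The steps to compound 4 from compound 2 and from compound 3 therefore cannot be read. The compounds shown leave open whether changing this group alters the cytotoxicity at all.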